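The source may hold more compounds than are shown below. What is called first, only, known or untested is meant among the compounds shown, and "the series" means these compounds.

Of the compounds shown here, two have numbers so far. Compound 1 `ClCc1ccccc1Cn1cnc2c(Cl)ncnc21` in a functional assay on K562 cells (Homo sapiens) for cytotoxicity, read by sulforhodamine B assay, with a stated time of 48 h (a lower number here means a stronger inhibitor of growth, a higher number a weaker inhibitor of growth), gives 5120 nM. Compound 2 `ClCc1cccc(Cn2cnc3c(Cl)ncnc32)c1` in this assay gives 15100 nM, the higher of the two numbers; the gap to compound 1 is beyond the scatter, so compound 2 is the weaker inhibitor of growth of the two. Compound 3 `ClCc1cccc(Cn2cnc3c(Cl)nc(Cl)nc32)c1` has not been measured. It differs from compound 2 in one place: chloro in place of hydrogen on an aromatic carbon. Among the measured compounds shown here, no pair of measured compounds shows the effect of this change, so the data give no guide to its size or direction. The expected step is a 1.3-fold lower number from compound 2 to compound 3 (0.10 log units; within the scatter), which is taken to be of no size beyond the scatter, with either direction open. Compound 3 is therefore expected to give about 12000 nM in this assay, estimated within a range from 4000 nM to 40000 nM.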

Compound 3, concentration for total growth inhibition: > 100000 nM
Compound 3 was reported as a limit; the forecaster's own chance of this, stated with the estimate: 5%; middle value at least 8.3-fold (0.92 log units) from the limit.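

Chloro in place of hydrogen on the aromatic carbon between two ring nitrogen atoms gives an at least 6.6-fold higher number from compound 2 to compound 3 (0.82 log units; beyond the scatter) in this assay, so this carbon is not indifferent to substitution and compound 3 is the weaker inhibitor of growth of the pair. Compound 1 and compound 2 both carry hydrogen at this carbon, so they gave no reading of a change here. Compound 3 stands as a limit, > 100000 nM, and not as a number, so the step gives only a lower bound on the size of the change: the limit of > 100000 nM in this assay, at which 1 of the 3 values shown sits.

With chloro the only group shown at this carbon, it remains open whether an amine or a methoxy group there would bring the same loss. On these data alone, whether the same change has a like effect on compound 1 also stays open.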